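The compounds below may be only part of what the source reports. "The series", "measured", "known", "first", "only" and "open" are said of these compounds alone.

Compound 3 `O=C(NS(=O)(=O)c1ccccc1)n1ccc2cc(Br)cnc21` has the lowest of the three numbers in a functional assay on HT-29 cells (Homo sapiens) for antiproliferative activity, read by MTT assay, with a stated time of 24 h, tested at 10 uM (a lower number here means less inhibition, a higher number more inhibition at the concentration tested (going by the name of the read-out)), giving 14.6%. The nearest to it is compound 1 `O=C(NS(=O)(=O)c1ccccc1)n1ccc2cccnc21`, which gives 23.6%, and the step of a number 9 percentage points lower from compound 1 to compound 3 (within the scatter) lies within the scatter. Compound 2 `Cc1ccc(S(=O)(=O)NC(=O)n2ccc3cccnc32)cc1` gives 33.4%, and it stands beyond the scatter from compound 3. Compound 4 `Cc1ccc(S(=O)(=O)NC(=O)n2ccc3cc(Br)cnc32)cc1` is not yet measured. It differs from compound 3 in one place: methyl in place of hydrogen on an aromatic carbon.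

For the measured compounds named here, one measured step bears directly on this change, the same swap made on the same part of the structure: a number 9.8 percentage points higher from compound 1 to compound 2 (within the scatter), a step that stays within the scatter. On that basis the step from compound 3 to compound 4 is expected to be an upward one of similar size, again within the scatter, namely a number 9.4 percentage points higher from compound 3 to compound 4 (within the scatter). Compound 4 is therefore estimated to give 24% in this assay, within a range from 10% to 38%.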

Compound 4, a percentage reported as inhibition, at one concentration (the size of the read-out at that concentration, not a potency): 82.4%
Compound 4: middle estimate off by 58.4 percentage points, on the low side; measured number outside the range, above it.
By their numbers in this assay, from the lowest: compounds 3, 1 and 2 (each within the scatter of the next, the first and the last beyond it); then compound 4.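

In this assay, the change from phenyl to 4-methylphenyl does not add a fixed amount; on the core carrying bromo it gives a number 67.8 percentage points higher from compound 3 to compound 4 (beyond the scatter), so its size depends on what else the molecule holds: the same change on two cores in this assay, a number 9.8 percentage points higher (within the scatter) from compound 1 to compound 2 and a number 67.8 percentage points higher (beyond the scatter) from compound 3 to compound 4, 58 percentage points apart, beyond the scatter of two such steps
The bromo depends on its partner in the same way, giving a number 49 percentage points higher from compound 2 to compound 4 (beyond the scatter) when the methyl is present, while the step without the methyl stays within the scatter: the same change on two cores in this assay, a number 9 percentage points lower (within the scatter) from compound 1 to compound 3 and a number 49 percentage points higher (beyond the scatter) from compound 2 to compound 4, 58 percentage points apart, beyond the scatter of two such steps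
The two groups therefore cannot be scored separately in this series, since the worth of each is seen only alongside the other.

The compounds shown leave open whether chloro on the core would do what bromo does, and whether ethyl or an amine in place of the methyl would keep the large step. They also do not tell why the two groups work together, and a reading at one concentration gives no potency.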